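A few compounds are considered here, and "the series" means these few. Any claim that something is new, unique, unknown or untested is made for them only; others in the source may bear on it.

Measured in a functional assay on MCF7 cells (Homo sapiens) for cytotoxicity, read by MTT assay, with a stated time of 24 h; a higher number here means a weaker inhibitor, a lower number a stronger inhibitor:
- compound 1 `O=c1nc2ccc(Br)cn2cc1Cc1ccc(Br)cc1`: 97200 nM
- compound 2 `COc1ccc(Cc2cn3cc(Br)ccc3nc2=O)cc1`: > 1000000 nM (a limit)
- compound 3 `Cc1ccc(Cc2cn3cc(Cl)ccc3nc2=O)cc1`: > 1000000 nM (a limit)

Compound 2 stands at the limit of > 1000000 nM in this assay, at which 2 of the 3 values shown sit; this is a limit, not a number. Compound 4 `O=c1nc2ccc(Br)cn2cc1Cc1ccc(Cl)cc1` changes one group of compound 2, with chloro in place of methoxy on an aromatic carbon, para to a large group: chloro in place of methoxy on an aromatic carbon. Going by the values given here, the one measured step that bears on this swaps the same spot, methoxy in place of bromo, and it is large: an at least 10-fold higher number from compound 1 to compound 2 (1.01 log units; beyond the scatter). Losing the methoxy is therefore expected to bring a large step towards a lower number in this assay, meaning a stronger inhibitor, though chloro is not bromo and the size is uncertain. The expected change is an at least 6.6-fold lower number from compound 2 to compound 4 (0.82 log units; beyond the scatter). The estimate for compound 4 is 150000 nM, with an expected range from 40000 nM to 600000 nM.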

Compound 4, half-maximal inhibitory concentration: > 1000000 nM
Compound 4: no number, only a limit; the forecaster's own chance of this, stated with the estimate: 25%; middle value at least 6.6-fold (0.82 log units) from the limit.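

In this assay, the earlier step showed a loss only for methoxy, a group quite unlike bromo, yet here the much closer swap of chloro for bromo also gives an at least 10-fold higher number from compound 1 to compound 4 (1.01 log units; beyond the scatter). At this spot, then, bromo is the only group shown that keeps a measurable value, and the loss is not confined to methoxy. Compound 4 gives only a limit, and the step between compound 2 and compound 4 cannot be read: the limit of > 1000000 nM in this assay, at which 3 of the 4 values shown sit.

As far as these compounds go, whether iodo or an amine at this spot would give a measurable value stays open. So does whether any group here could give a lower number than compound 1.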